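Methoxy for methyl on the aniline ring of compound 3

This account rests on a few compounds, and the source may have more. Where it says the series, first, only, none or still open, it means among the compounds named here.

Measured so far:
- compound 1 `c1coc(-c2ccnc(Nc3ccc(-n4ccnc4)cc3)n2)c1`: 2200 nM
- compound 2 `CN(C)c1ccc(Nc2nccc(-c3ccco3)n2)cc1`: 1900 nM
- compound 3 `Cc1cccc(Nc2nccc(-c3cc(C)oc3C)n2)c1`: 28500 nM

In a functional assay for inhibition, with Homo sapiens as the target (on this read-out lower numbers stand for stronger inhibition and higher numbers for weaker inhibition), compound 3 gives the highest number of the three, well beyond the scatter from both compound 1 and compound 2. For the measured compounds named here, the only step between measured compounds, a 1.2-fold lower number from compound 1 to compound 2 (0.06 log units; within the scatter), concerns a different part of the molecule and stays within the scatter.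

Compound 4 `COc1cccc(Nc2nccc(-c3cc(C)oc3C)n2)c1` differs from compound 3 by methoxy in place of methyl on an aromatic carbon, the place being an aromatic carbon of a six-membered aromatic ring of carbon only, meta to a large group. Going by the values given here, no measured pair shows this change, and no measured pair alters that ring by a group of this kind, so nothing points to a step beyond the scatter in this assay. Compound 4 is therefore expected at 22000 nM, with a range of 8000 nM to 60000 nM. The expected step from compound 3 is a 1.3-fold lower number from compound 3 to compound 4 (0.11 log units; within the scatter), with wide uncertainty.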

Compound 4, half-maximal inhibitory concentration: 5800 nM
Compound 4: the middle estimate sits 3.8-fold (0.58 log units) above what was measured; measured number outside the range, below it.
By their numbers in this assay, from the lowest: compounds 2 and 1 (each within the scatter of the next); then compound 4; then compound 3.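

In this assay, for the compounds shown here, the aromatic carbon meta to a large group proves sensitive to what it carries: methoxy in place of methyl gives a 4.9-fold lower number from compound 3 to compound 4 (0.69 log units; beyond the scatter) and is the first single-place change to pass beyond the scatter. The earlier step of a 1.2-fold lower number from compound 1 to compound 2 (0.06 log units; within the scatter) stayed within the scatter and concerned dimethylamino in place of 1H-imidazol-1-yl, so it gave no sign that one group could move the number this far. No measurement at hand explains the step from methyl to methoxy.

Open, as far as these compounds go, is whether ethoxy, hydroxyl or an amine on the same aromatic carbon would move the number further or reverse the step. Also open, from the compounds shown here alone, is whether methoxy gives a step of similar size on the core of compound 1.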